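Swapping an indole for a benzodioxin in a cytotoxicity series

This account rests on a few compounds, and the source may have more. Where it says the series, first, only, none or still open, it means among the compounds named here.

Compound 1 `CC(C)N(Cc1cccc(OCCCCCC(=O)O)c1)C(=O)c1ccc(-c2ccncc2)cc1` and compound 2 `CC(C)N(Cc1cccc(OCCCCCC(=O)O)c1)C(=O)c1ccc(-c2ccc3[nH]ccc3c2)cc1` share one core and were tested in an ADME assay on Raji cells (Homo sapiens) for cytotoxicity, read by CellTiter-Glo and resazurin assay, with a stated time of 72 h; a higher number here means that more compound is needed for the effect, a lower number that less compound is needed. In this assay compound 1 gives only a limit, > 26000 nM. In this assay compound 2 likewise gives only a limit, > 26000 nM. The step that the two limits leave unreadable from compound 1 to compound 2 therefore has no readable size, both values resting at the limit of > 26000 nM in this assay, at which 2 of the 2 values shown sit. Compound 2 thus stands at the limit, and its value cannot be set apart from that of compound 1. Compound 3 `CC(C)N(Cc1cccc(OCCCCCC(=O)O)c1)C(=O)c1ccc(-c2ccc3c(c2)OCCO3)cc1` differs from compound 2 by 2,3-dihydro-1,4-benzodioxin-6-yl in place of 1H-indol-5-yl on an aromatic carbon. Going by the values given here, the only measured step, a step that the two limits leave unreadable from compound 1 to compound 2, exchanges the group on the same aromatic carbon and gives no readable size. For compound 3 in this assay the expected step that the limit leaves unreadable from compound 2 to compound 3 is none beyond the scatter, most likely ending again at the limit. Compound 3 is estimated at 40000 nM, within 15000 nM to 150000 nM.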

Compound 3, half-maximal effective concentration: > 21900 nM
Compound 3: only a limit was reported (the forecaster's own chance of this, stated with the estimate: 85%); the middle value is on the limit's open side.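

Going by these compounds alone, no step among compound 1, compound 2 and compound 3 can be read in this assay, as all three values are limits. The compounds shown leave open whether the pyridin-4-yl, 1H-indol-5-yl and 2,3-dihydro-1,4-benzodioxin-6-yl groups differ at all in half-maximal effective concentration.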